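A few compounds are considered here, and "the series" means these few. Any claim that something is new, unique, unknown or untested is made for them only; others in the source may bear on it.

The measured compounds:
compound 1, `CC(=O)NCc1cccc(Cn2nc(NS(=O)(=O)c3ccc(Cl)s3)c3ccccc32)c1`, >= 117 ug/mL
compound 2, `CC(=O)NCc1cccc(Cn2nc(NS(=O)(=O)c3ccc(Cl)s3)c3c(O)cccc32)c1`, >= 166 ug/mL

Compound 1 was read in a physicochemical assay for solubility, read by chemiluminescence, measured as kinetic solubility (on this read-out lower numbers stand for lower solubility and higher numbers for higher solubility), and gives >= 117 ug/mL; this value is a limit of the assay, as recorded at the limit of >= 117 ug/mL in this assay, at which 1 of the 2 values shown sits. In this assay compound 2 gives >= 166 ug/mL, which is likewise a limit of the assay, recorded at the limit of >= 166 ug/mL in this assay, at which 1 of the 2 values shown sits. Compound 2 thus stands at a limit, with no exact number beneath it. The change from compound 1 to compound 2 is hydroxy in place of hydrogen on an aromatic carbon; with both ends being limits, the step that the two limits leave unreadable from compound 1 to compound 2 cannot be sized in either direction.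

Compound 3, `CC(=O)NCc1cccc(Cn2nc(NS(=O)(=O)c3ccc(Cl)s3)c3c(C(C)=O)cccc32)c1`, differs from compound 2 by acetyl in place of hydroxy on an aromatic carbon. Among the measured compounds shown here, no measured step covers this exchange, and the one measured step, a step that the two limits leave unreadable from compound 1 to compound 2, remains unreadable, so no direction can be taken from it. The step of an at least 1.6-fold lower number from compound 2 to compound 3 (0.22 log units; that floor lies within the scatter) is therefore expected to stay within the usual scatter, without a clear direction. Compound 3 is estimated to give 100 ug/mL in this assay, within a range from 30 ug/mL to 200 ug/mL.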

Compound 3, solubility: 57 ug/mL
The estimate for compound 3 lay 1.8-fold (0.24 log units) above the measured number, and the stated range covers the measured number.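

In this assay, among the compounds shown here, this aromatic carbon, ortho to a fused ring, shows for the first time a change that can be read beyond the scatter: acetyl in place of hydroxy gives an at least 2.9-fold lower number from compound 2 to compound 3 (0.46 log units; beyond the scatter), and acetyl in place of hydrogen gives an at least 2.0-fold lower number from compound 1 to compound 3 (0.31 log units; beyond the scatter). Compound 2 stands at a limit of the assay, so the first of these steps is a floor and not a full size: the limit of >= 166 ug/mL in this assay, at which 1 of the 3 values shown sits.
Compound 1 also stands at a limit, so the second step is a floor as well, and the step between compound 1 and compound 2 cannot be read: the limit of >= 117 ug/mL in this assay, at which 1 of the 3 values shown sits.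

On these data alone, whether an amine, a carboxylic acid or a longer acyl chain such as propanoyl on this same aromatic carbon would give a number close to that of compound 3 stays open. Also open, as far as these compounds go, are the true distance of compound 1 and compound 2 from compound 3 and whether the exchange of hydroxy for acetyl would give a step of the same direction on any other core.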